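Melanocortin receptor 4 series: side-chain change at the amide carbonyl

The compounds below may be only part of what the source reports. "The series", "measured", "known", "first", "only" and "open" are said of these compounds alone.

Measured so far:
compound 1 `COc1cc(Cl)ccc1C[C@@H](C)C(=O)N1CCN(c2ccc(C)cc2[C@@H](N)CC(C)C)CC1` — 8.1 nM
compound 2 `CC(C)C[C@H](N)c1cc(C(F)(F)F)ccc1N1CCN(C(=O)C(C)Cc2ccc(Cl)cc2O)CC1` — 36 nM

For the measured compounds named here, in an assay on HEK293 cells for displacement of a labelled ligand from Melanocortin receptor 4 (Homo sapiens) (a higher number here means a weaker inhibitor, a lower number a stronger inhibitor), compound 2 gives 36 nM, the higher of the two numbers so far. Going by the values given here, compound 1, the only other measured compound, gives 8.1 nM; the gap between the two is beyond the usual scatter, and the two structures differ in more than one place, so no single cause can be read from it.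

Compound 3 `CC(C)C[C@H](N)c1cc(C(F)(F)F)ccc1N1CCN(C(=O)CC(C)C(=O)c2ccc(Cl)cc2)CC1` has not yet been measured in this assay. Relative to compound 2 the change is 2-((4-chlorophenyl)carbonyl)propyl in place of 1-(4-chloro-2-hydroxybenzyl)ethyl on a carbonyl carbon. Among the compounds with values here, no pair of measured compounds shows a step of this kind, so the direction rests on judgement alone.

The expected step from compound 2 to compound 3 is a 2.5-fold higher number from compound 2 to compound 3 (0.40 log units; beyond the scatter), toward a higher number, probably beyond the scatter. Compound 3 is estimated at 90 nM, with a range of 25 nM to 350 nM.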

Compound 3, inhibition constant: 1100 nM
Estimate against measurement, compound 3: 12-fold (1.09 log units) below, and the stated range ends below it.
By their numbers in this assay, from the lowest: compound 1; then compound 2; then compound 3.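

In this assay the exchange of 1-(4-chloro-2-hydroxybenzyl)ethyl for 2-((4-chlorophenyl)carbonyl)propyl on the carbonyl carbon gives a 31-fold higher number from compound 2 to compound 3 (1.49 log units; beyond the scatter) and shows that this position is sensitive to the make-up of the side chain, even though both groups carry one chlorinated six-membered aromatic ring. The exchange removes the hydrogen-bond donor, adds a double bond outside aromatic rings and rearranges the chain, all in a single step. No independent data bear on the origin of the large loss.

The compounds shown do not separate the loss of the hydroxy group from the rearrangement of the chain. An amine in place of that hydroxy group, with the 1-benzylethyl chain kept, would bear on the first question, and the reduced alcohol of the 2-((4-chlorophenyl)carbonyl)propyl chain on the second.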